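The compounds below may be only part of what the source reports. "The series", "measured", "known", "first", "only" and "open" are said of these compounds alone.

Compound 1 `CCC(C)C1NC(=O)N(C2CCCC2)C1=O` gives > 100000 nM in a functional assay on HeLa cells (Homo sapiens) for inhibition (a lower number here means a stronger inhibitor, a higher number a weaker inhibitor), a limit of the assay.
Compound 2 `CC(C)C(NC(=O)NO)C(=O)NC1CCCC1` gives > 100000 nM in this assay, also a limit.
Compound 3 `CC(C)C1NC(=O)N(C2CCCC2)C1=O` gives > 100000 nM in this assay, again a limit.

From compound 3 to compound 1 the change is methyl in place of hydrogen on a saturated chain carbon, two bonds along the chain from a saturated ring carbon, and the step it made, a step that the two limits leave unreadable from compound 3 to compound 1, cannot be read because the limit of > 100000 nM in this assay, at which 3 of the 3 values shown sit, holds both ends. The difference between the core of compound 2 and that of compound 3 is not broken down here. Compound 4 `CCC(C)C(NC(=O)NO)C(=O)NC1CCCC1` stands to compound 2 as compound 1 does to compound 3: the change is methyl in place of hydrogen on a saturated chain carbon, three bonds along the chain from an amide-type nitrogen and a carbonyl carbon, the same kind of change, though the place differs, here three bonds along the chain from an amide-type nitrogen and a carbonyl carbon rather than two bonds from a saturated ring carbon. Since the earlier step is unreadable, the expectation for compound 4 rests only on compound 2 sitting at its limit, and the step that the limit leaves unreadable from compound 2 to compound 4 is expected to leave it there. Compound 4 is estimated at 150000 nM in this assay, between 30000 nM and 1000000 nM.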

Compound 4, half-maximal inhibitory concentration: > 100000 nM
Compound 4: only a limit was reported (the forecaster's own chance of this, stated with the estimate: 85%); the middle value is on the limit's open side.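

No step can be read from compound 2 to compound 4, because both ends sit at the same limit: the limit of > 100000 nM in this assay, at which 4 of the 4 values shown sit.

The compounds shown leave open how strongly any of them inhibits in this assay, and what methyl in place of hydrogen does on either core.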